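The compounds below may be only part of what the source reports. "The series", "measured", "known", "first", "only" and "open" are said of these compounds alone.

Compound 1 `CC1=NC(C)=C(C(=O)O)C(c2cccc(Cl)c2)/C1=C(\O)OC/C=C/C1CCCCC1` gives 830 nM in a functional assay on IMR-32 cells for inhibition of Voltage-dependent N-type calcium channel subunit alpha-1B (Homo sapiens), read by calcium flux; a lower number here means a stronger inhibitor, a higher number a weaker inhibitor; compound 2 `CC1=NC(C)=C(C(=O)O)C(c2cccc(Cl)c2)/C1=C(\O)OC/C=C/c1ccc(Cl)cc1` gives 1500 nM; compound 3 `CC1=NC(C)=C(C(=O)O)C(c2cccc(Cl)c2)/C1=C(\O)OC/C=C/c1ccncc1` gives 6200 nM.

Compound 3 has the highest number of the three, and its steps to both others lie beyond the scatter: a 7.5-fold higher number from compound 1 to compound 3 (0.87 log units; beyond the scatter) and a 4.1-fold higher number from compound 2 to compound 3 (0.62 log units; beyond the scatter). Compound 4 `CC1=NC(C)=C(C(=O)O)C(c2cccc(Cl)c2)/C1=C(\O)OC/C(C)=C/c1ccccc1` arises from compound 3 by the change (1-methyl-2-phenylethenyl in place of 2-(pyridin-4-yl)ethenyl on a saturated chain carbon bound to an oxygen on an unsaturated carbon). Within the data shown here, the steps that bear on this are those in which a ring of carbon only gave way to the pyridine ring, a 4.1-fold higher number from compound 2 to compound 3 (0.62 log units; beyond the scatter) and a 7.5-fold higher number from compound 1 to compound 3 (0.87 log units; beyond the scatter), each raising the number. Undoing that in compound 4 is therefore expected to lower the number by a modest step, a 4.1-fold lower number from compound 3 to compound 4 (0.62 log units; beyond the scatter). Among the measured compounds shown here, no measured compound carries the methyl of 1-methyl-2-phenylethenyl, so its contribution is unknown. Compound 4 is estimated at 1500 nM, in the range 600 nM to 4000 nM.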

Compound 4, half-maximal inhibitory concentration: 680 nM
Beside the measured number, compound 4's estimate is 2.2-fold (0.34 log units) above it; the range from low to high includes it.
By their numbers in this assay, from the lowest: compounds 4, 1 and 2 (each within the scatter of the next, the first and the last beyond it); then compound 3.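

In this assay the 1-methyl-2-phenylethenyl group gives a large gain over the pyridine-bearing group, with a 9.1-fold lower number from compound 3 to compound 4 (0.96 log units; beyond the scatter) on this saturated chain carbon. It also separates from the chlorinated aryl group, with a 2.2-fold lower number from compound 2 to compound 4 (0.34 log units; beyond the scatter) beyond the scatter, whereas the cyclohexyl comparison shows a 1.2-fold lower number from compound 1 to compound 4 (0.09 log units; within the scatter) and stays within it. No measurement here accounts for these differences.

From the compounds shown here alone, what the methyl contributes alone stays open, as every step to compound 4 changes the ring as well. Also open, going by these compounds, is how an amine or a carboxylic acid on the phenyl ring would fare at this position.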